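Cyclohexyl on the amide-type nitrogen: working notes

The source may hold more compounds than are shown below. What is called first, only, known or untested is meant among the compounds shown, and "the series" means these compounds.

Compound 1 `CC(C)NC(=O)CCC(=O)c1cccc(C(F)(F)F)c1` and compound 2 `CC(C)CNC(=O)CCC(=O)c1cccc(C(F)(F)F)c1` share one core and differ only in the group on an amide-type nitrogen. In a functional assay on the whole organism with Mus musculus as the target (on this read-out lower numbers stand for an effect already at smaller amounts and higher numbers for an effect only at larger amounts of compound), compound 1 gives > 200 mg/kg as a limit of the assay. In this assay compound 2 gives > 200 mg/kg as a limit too. The evidence so far is the limit of > 200 mg/kg in this assay, at which 2 of the 2 values shown sit, and no number, so compound 2 stands on a limit alone. Going by the values given here, the one measured step is a step that the two limits leave unreadable from compound 1 to compound 2 and gives no size or direction to carry over. Among the compounds with values here, compound 3 `O=C(CCC(=O)c1cccc(C(F)(F)F)c1)NC1CCCCC1` has cyclohexyl in place of isobutyl on an amide-type nitrogen, and the difference cyclohexyl in place of isobutyl on an amide-type nitrogen is the only change. Another limit is the likeliest result, and the expectation rests on compound 2 with its > 200 mg/kg as a limit. The expected change is a step that the limit leaves unreadable from compound 2 to compound 3 and remains only an estimate. For compound 3 the estimate is 220 mg/kg with 90 mg/kg to 500 mg/kg as the expected range.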

Compound 3, dose for half-maximal effect: > 200 mg/kg
Compound 3: a limit, no number; the forecaster's own chance of this, stated with the estimate: 70%; the middle value lies beyond the limit too.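

No step among compound 1, compound 2 and compound 3 can be read, since each result is a limit and not a number: the limit of > 200 mg/kg in this assay, at which 3 of the 3 values shown sit.

The compounds shown leave open whether isopropyl, isobutyl and cyclohexyl on an amide-type nitrogen differ at all in this assay.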